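This account rests on a few compounds, and the source may have more. Where it says the series, first, only, none or still open, it means among the compounds named here.

In a functional assay on RKOp27 cells (Homo sapiens) for cytotoxicity, read by MTT assay, with a stated time of 3 days (a higher number here means a weaker inhibitor, a lower number a stronger inhibitor), compound 2 (`CCNc1nc(SCc2nc3ccccc3[nH]2)nc(-c2ccccc2)c1C#N`) gives 7.35 nM and cannot be separated from compound 1 (`N#Cc1c(Nc2ccccc2)nc(SCc2nc3ccccc3[nH]2)nc1-c1ccccc1`) at 4.9 nM or from compound 3 (`N#Cc1c(Nc2ccccn2)nc(SCc2nc3ccccc3[nH]2)nc1-c1ccccc1`) at 3.8 nM. Every step among the three stays within the scatter.

The next change leads to compound 4 (`CN1CCN(c2nc(SCc3nc4ccccc4[nH]3)nc(-c3ccccc3)c2C#N)CC1`), with 4-methylpiperazin-1-yl in place of ethylamino on an aromatic carbon. Among the compounds with values here, three measured steps concern this same place: a 1.5-fold higher number from compound 1 to compound 2 (0.18 log units; within the scatter) and a 1.3-fold lower number from compound 1 to compound 3 (0.11 log units; within the scatter) and a 1.9-fold lower number from compound 2 to compound 3 (0.29 log units; within the scatter) are all within the scatter. They bear on the change only in part, since each of these compounds keeps a hydrogen on the attached nitrogen and none carries the 4-methylpiperazin-1-yl group.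

Going by those small steps, no shift beyond the scatter is expected in this assay and any drift is expected to be slight, towards a higher number. The expected change is a 1.4-fold higher number from compound 2 to compound 4 (0.13 log units; within the scatter) and this estimate carries real uncertainty. For compound 4 the estimated value is 10 nM with an expected range of 2.5 nM to 40 nM in this wide form.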

Compound 4, half-maximal inhibitory concentration: 5.4 nM
Compound 4: the middle estimate sits 1.9-fold (0.27 log units) above what was measured; measured number inside the range.
By their numbers in this assay, from the lowest: compounds 3, 1, 4 and 2 (each within the scatter of the next).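

In this assay, within the data shown here, the earlier compounds all kept a hydrogen on the attached nitrogen, whereas the 4-methylpiperazin-1-yl group has no hydrogen-bond donor and brings a six-membered non-aromatic ring to this aromatic carbon. Even so, the number stays within the scatter of all three earlier compounds: a 1.4-fold lower number from compound 2 to compound 4 (0.13 log units; within the scatter) and a 1.4-fold higher number from compound 3 to compound 4 (0.15 log units; within the scatter) and a 1.1-fold higher number from compound 1 to compound 4 (0.04 log units; within the scatter) so, among these four compounds, neither that hydrogen nor the ring separates the values in this assay. No measurement here accounts for this flat result.

On these data alone, whether any group on this carbon can move the number beyond the scatter remains open, for example a carboxylic acid or a longer alkyl chain. The role of the methyl group also stays open, as the unsubstituted piperazin-1-yl group is not among the compounds shown.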